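Compound 1 to compound 4: replacing phenylcarbamoyl

This account rests on a few compounds, and the source may have more. Where it says the series, first, only, none or still open, it means among the compounds named here.

Measured in an ADME assay on microsomes from liver (Homo sapiens) for metabolic stability, read by LC-MS, using NADPH, with stated times of 5 min and 30 min, tested at 1 uM; a lower number here means slower removal, a higher number faster removal of the compound:
- compound 1 `O=C(Nc1ccccc1)c1cnc(NCc2c(F)ccc3c2CCO3)n2cnnc12` gives 14 mL.min-1.g-1
- compound 2 `Cn1cc(-c2cnc(NCc3c(F)ccc4c3CCO4)c3cn[nH]c(=O)c23)cn1` gives 21 mL.min-1.g-1
- compound 3 `Cc1nccn1-c1cnc(NCc2c(F)ccc3c2CCO3)c2cn[nH]c(=O)c12` gives 8 mL.min-1.g-1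

Compound 1 holds the second highest of the three numbers, but it lies within the scatter of both compound 2 and compound 3. Compound 4 `COCCC(=O)Nc1cnc(NCc2c(F)ccc3c2CCO3)n2cnnc12` is still to be measured. It carries ((2-methoxyethyl)carbonyl)amino in place of phenylcarbamoyl on an aromatic carbon of the core of compound 1: ((2-methoxyethyl)carbonyl)amino in place of phenylcarbamoyl on an aromatic carbon.

One measured step exists, a 2.6-fold lower number from compound 2 to compound 3 (0.42 log units; beyond the scatter). It is modest, involves other groups and sits on the different core shared by compound 2 and compound 3, so it bears on this change only loosely. Within the data shown here, no measured step removes phenylcarbamoyl, and the direction remains uncertain. No step beyond the scatter is therefore expected in this assay. The estimated step is a 1.3-fold lower number from compound 1 to compound 4 (0.10 log units; within the scatter). Compound 4 is expected at 11 mL.min-1.g-1, with an estimated range of 5 mL.min-1.g-1 to 24 mL.min-1.g-1.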

Compound 4, intrinsic clearance in microsomes: < 3 mL.min-1.g-1
Compound 4: only a limit was reported; the forecaster's own chance of this, stated with the estimate: 3%; middle value at least 3.6-fold (0.56 log units) from the limit.
By their numbers in this assay, from the lowest: compounds 3, 1 and 2 (each within the scatter of the next, the first and the last beyond it). At a limit, below all of these: compound 4.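

Replacing phenylcarbamoyl with ((2-methoxyethyl)carbonyl)amino on this aromatic carbon gives an at least 4.6-fold lower number from compound 1 to compound 4 (0.66 log units; beyond the scatter) in this assay, so the group at this position of the core of compound 1 can shift the number beyond the scatter. Compound 4 is reported only as a limit, not as a number: the limit of < 3 mL.min-1.g-1 in this assay, at which 1 of the 4 values shown sits.

Among these compounds, the only earlier step beyond the scatter, a 2.6-fold lower number from compound 2 to compound 3 (0.42 log units; beyond the scatter), sits on a different core and says nothing about this position.

The compounds shown do not separate the loss of the six-membered aromatic ring from the change in attachment, carbonyl to amino, or from the 2-methoxyethyl chain itself. A benzoylamino group, an acetylamino group or a simple amine on the same aromatic carbon would show which part of the change carries the step.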